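The source may report more compounds than this note shows. Statements on the series, on what has been measured and on what is new or still open speak of the compounds shown alone.

Measured so far:
compound 1 `CC(C)=CCC/C(C)=C\Cn1cc(COc2ccccc2O)nn1` — > 20000 nM
compound 2 `CCCCCc1cn(Cc2ccccc2O)nn1` — > 20000 nM

Both entries in an ADME assay on Vero cells (Chlorocebus sabaeus) for cytotoxicity, read by neutral red uptake, with a stated time of 48 h (on this read-out lower numbers stand for stronger inhibition and higher numbers for weaker inhibition), are limits of the assay rather than numbers. Compound 1 gives > 20000 nM in this assay, a limit. Compound 2 likewise gives > 20000 nM in this assay, again a limit. Among the compounds with values here, compound 2 thus stands at the limit of this assay, and no step between measured compounds can be drawn, since every value shown is a limit (the limit of > 20000 nM in this assay, at which 2 of the 2 values shown sit). Compound 3 `Oc1ccccc1Cn1cc(-c2ccccc2)nn1` is yet to be measured in this assay. The change from compound 2 is phenyl in place of pentyl on an aromatic carbon. Compound 2 sits at a limit. The step from compound 2 to compound 3 is accordingly expected to be none beyond the scatter, estimated as a step that the limit leaves unreadable from compound 2 to compound 3. Compound 3 is therefore expected to sit at 30000 nM, within 15000 nM to 80000 nM, most likely once more reported only as a limit of this assay.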

Compound 3, half-maximal inhibitory concentration: > 20000 nM
Compound 3: no number, only a limit (the forecaster's own chance of this, stated with the estimate: 80%); the middle value does not contradict the limit.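

In this assay, no step can be read between compound 2 and compound 3, since both values are limits: the limit of > 20000 nM in this assay, at which 3 of the 3 values shown sit.

The compounds shown leave open where the actual values of compound 1, compound 2 and compound 3 lie, and whether phenyl and pentyl differ at all in this assay.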